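Cytotoxicity notes on three measured analogues and one pending

The compounds below may be only part of what the source reports. "The series", "measured", "known", "first", "only" and "open" are said of these compounds alone.

Compound 1 `CCc1ccc(-c2nc3c(c(C)nn3-c3ccccc3)c(-c3ccccc3Cl)c2C#N)cc1`: in an ADME assay on BJ cells (Homo sapiens) for cytotoxicity, with a stated time of 72 h (a lower number here means that less compound is needed, a higher number that more compound is needed for the effect), compound 1 gives > 20000 nM, which is a limit of the assay.
Compound 2 `CCc1ccc(-c2nc3c(c(C)nn3-c3ccccc3)c(-c3ccccc3F)c2C#N)cc1`: in this assay compound 2 gives > 20000 nM, also a limit.
Compound 3 `Cc1nn(-c2ccccc2)c2nc(-c3ccc(F)cc3)c(C#N)c(-c3ccccc3O)c12`: in this assay compound 3 gives > 20000 nM, again a limit.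

The change from compound 2 to compound 1 is chloro in place of fluoro on an aromatic carbon, and its step that the two limits leave unreadable from compound 2 to compound 1 cannot be read, due to the limit of > 20000 nM in this assay, at which 3 of the 3 values shown sit. The difference between the cores of compound 2 and compound 3 is not broken down here. Compound 4 `Cc1nn(-c2ccccc2)c2nc(-c3ccc(Cl)cc3)c(C#N)c(-c3ccccc3O)c12` is not yet measured; it differs from compound 3 by chloro in place of fluoro on an aromatic carbon. This is the same kind of change as that from compound 2 to compound 1, but here the place is para to a large group, whereas there it is ortho to a large group. For compound 4 the step that the limit leaves unreadable from compound 3 to compound 4 is expected to be small, resting on the unreadable step that the two limits leave unreadable from compound 2 to compound 1 and on (the limit of > 20000 nM in this assay, at which 3 of the 3 values shown sit). Compound 4 is expected to give 30000 nM, most likely again only a limit, within a range from 15000 nM to 100000 nM.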

Compound 4, half-maximal effective concentration in the BJ assay: > 20000 nM
Compound 4 ended at the assay's limit (the forecaster's own chance of this, stated with the estimate: 90%); the middle value is on the limit's open side.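

In the BJ assay compound 3 gives > 20000 nM, which is a limit of the assay. In the BJ assay compound 4 gives > 20000 nM, also a limit. In the BJ assay the step between compound 3 and compound 4 cannot be read, due to the limit: the limit of > 20000 nM in the BJ assay, at which 4 of the 4 values shown sit.
The compounds shown leave open where any effective concentration lies, and whether chloro in place of fluoro shifts it. In a physicochemical assay for solubility, read by spectrophotometry, in phosphate buffer, with a stated time of 18 h, at pH 7.4 (a higher number here means a more soluble compound, a lower number a less soluble compound), compound 3 gives 6000 nM and compound 4 gives 3800 nM, which is a 1.6-fold lower number from compound 3 to compound 4 (0.20 log units; within the scatter).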